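Carbamate on the Aromatic Oxygen of a Prenylated Core

A few compounds are considered here, and "the series" means these few. Any claim that something is new, unique, unknown or untested is made for them only; others in the source may bear on it.

Three compounds were tested in a functional assay on PANC-1 cells (Homo sapiens) for inhibition, read by MTT assay, with a stated time of 24 h, tested at 10 uM; a higher number here means more inhibition at the concentration tested (going by the name of the read-out), a lower number less inhibition:
compound 1 `CC(C)=CCC1Cc2c(O)cc(=O)n(CCCO)c2CC1(C)C` gives 25.6%
compound 2 `CC(C)=CCC/C(C)=C/CC1Cc2c(O)cc(=O)n(CCCO)c2CC1(C)C` gives 28.7%
compound 3 `CC(C)=CCC1Cc2c(OCCCNC(=O)c3ccco3)cc(=O)n(CCCO)c2CC1(C)C` gives 2.1%

The step of a number 3.1 percentage points higher from compound 1 to compound 2 (within the scatter) lies within the scatter, so compound 2 and compound 1 are not separated on these numbers, while compound 3 sits clearly lower than either. Compound 4 `COc1ccc(NC(=O)Oc2cc(=O)n(CCCO)c3c2CC(C/C=C(\C)CCC=C(C)C)C(C)(C)C3)cc1` differs from compound 2 by (4-methoxyphenyl)carbamoyl in place of hydrogen on an oxygen on an aromatic ring. The step that bears on this is a number 23.5 percentage points lower from compound 1 to compound 3 (beyond the scatter), which likewise replaced hydrogen on the same aromatic-ring oxygen with a larger group and cost a modest but clear loss. A loss of comparable size is therefore expected, a number 20.7 percentage points lower from compound 2 to compound 4 (beyond the scatter). Compound 4 is estimated at 8%, with a range from -6% to 22%.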

Compound 4, a percentage reported as inhibition, at one concentration (the size of the read-out at that concentration, not a potency): 64.1%
The estimate for compound 4 lay 56.1 percentage points below the measured number, and the stated range ends below it.
By their numbers in this assay, from the lowest: compound 3; then compounds 1 and 2 (each within the scatter of the next); then compound 4.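

The step of a number 35.4 percentage points higher from compound 2 to compound 4 (beyond the scatter) shows that filling this oxygen on an aromatic ring does not have to lower the number: with (4-methoxyphenyl)carbamoyl in place of hydrogen, the read-out rises. The earlier change at the same oxygen went the other way, a number 23.5 percentage points lower from compound 1 to compound 3 (beyond the scatter), so the direction of the effect here depends on the group attached. Nothing available explains why this group raises the number.

Going by these compounds, it remains open whether the rise belongs to the carbamoyl link or to the 4-methoxyphenyl, which a plain phenyl or a 4-chlorophenyl on the same link would help separate. On these data alone, it is also open whether (4-methoxyphenyl)carbamoyl gives a similar step on compound 1, with its shorter 3-methylbut-2-en-1-yl chain.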